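Swapping oxygen for sulfur on a shared quinoxaline-type core

This account rests on a few compounds, and the source may have more. Where it says the series, first, only, none or still open, it means among the compounds named here.

Of the compounds shown here, three sharing one core have been measured in a functional assay on RXF 393 cells (Homo sapiens) for inhibition, read by sulforhodamine B assay, with a stated time of 48 h; on this read-out lower numbers stand for stronger inhibition of growth and higher numbers for weaker inhibition of growth. Compound 1 (`Nc1cc(N)c2nc(-c3ccccc3)c(Oc3ccc(Cl)c(Cl)c3)nc2c1`) gives 58900 nM. Compound 2 (`CCOC(=O)[C@H](CCC(=O)O)NC(=O)c1ccc(Sc2nc3cc(N)cc(N)c3nc2-c2ccccc2)cc1`) gives 74100 nM, which sits within the usual scatter of the value of compound 1. Compound 3 (`COc1ccc(CNc2nc3cc(N)cc(N)c3nc2-c2ccccc2)cc1`) gives 18200 nM, a clearly lower number than that of compound 1, so compound 1 stands second highest among the three. Compound 4 (`Nc1cc(N)c2nc(-c3ccccc3)c(Sc3ccc(Cl)c(Cl)c3)nc2c1`) has not been measured; it differs from compound 1 by (3,4-dichlorophenyl)sulfanyl in place of 3,4-dichlorophenoxy on an aromatic carbon. Among the measured compounds shown here, no measured pair isolates this exchange, so the step from compound 1 to compound 4 is expected to be small, with no change beyond the scatter in this assay, as a 1.2-fold lower number from compound 1 to compound 4 (0.07 log units; within the scatter). Compound 4 is therefore estimated at 50000 nM, between 20000 nM and 120000 nM.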

Compound 4, concentration for total growth inhibition: 26900 nM
Compound 4: the middle estimate sits 1.9-fold (0.27 log units) above what was measured, and the stated range covers the measured number.
By their numbers in this assay, from the lowest: compounds 3 and 4 (each within the scatter of the next); then compounds 1 and 2 (each within the scatter of the next).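

In this assay, among the compounds shown here, the exchange of 3,4-dichlorophenoxy for (3,4-dichlorophenyl)sulfanyl gives a 2.2-fold lower number from compound 1 to compound 4 (0.34 log units; beyond the scatter) and is the first step here that isolates a single change at this position. Changing only the atom that joins the dichlorophenyl ring to the shared core therefore moves the number modestly towards stronger growth inhibition. Nothing available explains this shift. As far as these compounds go, whether a sulfonyl link at this position would move the number further remains open. So does the effect of a nitrile in place of the two chlorines on the sulfur-linked ring.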